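Homologating the aryl ether of compound 2

This account rests on a few compounds, and the source may have more. Where it says the series, first, only, none or still open, it means among the compounds named here.

Compound 2 `C=CCOc1c(C)c(C)c2c(c1C)CCC(C)(COc1ccc(/C=C3\SC(=O)NC3=O)cc1OC)O2` gives the lowest number of the three measured in a functional assay on MCF7 cells (Homo sapiens), tested at 5 uM (on this read-out lower numbers stand for a stronger effect and higher numbers for a weaker effect at the one concentration tested), at 5%; compound 1 `C=CCOc1c(C)c(C)c2c(c1C)CCC(C)(COc1ccc(/C=C3\SC(=O)NC3=O)cc1)O2` gives 42% and compound 3 `CC(C)=CCOc1c(C)c(C)c2c(c1C)CCC(C)(COc1ccc(/C=C3\SC(=O)NC3=O)cc1-c1ccc(F)cc1)O2` gives 92%. Among the measured compounds shown here, the only step in the set, a number 37 percentage points lower from compound 1 to compound 2 (beyond the scatter), came from methoxy in place of hydrogen on an aromatic carbon. Compound 4 `C=CCOc1c(C)c(C)c2c(c1C)CCC(C)(COc1ccc(/C=C3\SC(=O)NC3=O)cc1OCC)O2` extends that methoxy: methyl in place of hydrogen on a saturated chain carbon bound to an oxygen on an aromatic ring. For the measured compounds named here, no measured pair shows a methoxy to ethoxy change, and compound 3 differs from compound 2 in more than one place, so the step from compound 1 to compound 2 is the only one that bears on it, and only indirectly. Because compound 2 already gives 5% with the aryl ether kept, the step of a number 5 percentage points higher from compound 2 to compound 4 (within the scatter) is expected to stay within the scatter. Compound 4 is estimated at 10%, in a range from 0% to 35%.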

Compound 4, a percentage reported as activity, at one concentration (the size of the read-out at that concentration, not a potency): 87%
Estimate against measurement, compound 4: 77 percentage points below; the measured number lies above the stated range.
By their numbers in this assay, from the lowest: compound 2; then compound 1; then compounds 4 and 3 (each within the scatter of the next).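

At this aromatic carbon, a single added methyl separates one of the lowest numbers from one of the highest in this assay (a number 82 percentage points higher from compound 2 to compound 4 (beyond the scatter)), so the result for methoxy does not extend to ethoxy. Ethoxy also reverses the direction seen with methoxy when each replaces hydrogen (a number 45 percentage points higher from compound 1 to compound 4 (beyond the scatter)). Nothing available explains this reversal.

As far as these compounds go, it remains open whether a hydroxyl group at this carbon would read like compound 2 or compound 4. A longer chain, such as propoxy, is equally unresolved.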